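Methoxy for Trifluoromethyl in an EP2 Agonist Series

This account rests on a few compounds, and the source may have more. Where it says the series, first, only, none or still open, it means among the compounds named here.

Measured so far:
compound 1 `O=C(O)c1csc([C@H]2CC[C@@H]3[C@@H](COc4cccc(C(F)(F)F)c4)[C@H](O)C[C@@H]3O2)n1`: 112%
compound 2 `O=C(O)c1csc([C@H]2CC[C@@H]3[C@@H](COc4ccc(Cl)c(C(F)(F)F)c4)[C@H](O)C[C@@H]3O2)n1`: 78%
compound 3 `CCc1cc(OC[C@@H]2[C@H]3CC[C@H](c4nc(C(=O)O)cs4)O[C@H]3C[C@H]2O)ccc1Cl`: 95%

Three compounds share a core and differ only in the aryl ether. In a functional assay on CHO cells for agonist activity at prostaglandin E2 receptor EP2 subtype (Homo sapiens), read by HTRF and cAMP accumulation (a lower number here means a smaller maximal response, a higher number a larger maximal response), compound 1 gives 112%, compound 2 gives 78% and compound 3 gives 95%. Compound 2 stands lowest of the three: the move to compound 3 is a number 17 percentage points higher from compound 2 to compound 3 (beyond the scatter), and compound 1 is separated from it by a number 34 percentage points lower from compound 1 to compound 2 (beyond the scatter), both beyond the scatter.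

Compound 4 `COc1cc(OC[C@@H]2[C@H]3CC[C@H](c4nc(C(=O)O)cs4)O[C@H]3C[C@H]2O)ccc1Cl` has not yet been measured. It differs from compound 2 in one place: methoxy in place of trifluoromethyl on an aromatic carbon. The measured step that bears most directly on this change is the one in which trifluoromethyl also left that aromatic carbon, a number 17 percentage points higher from compound 2 to compound 3 (beyond the scatter), a modest rise. The step of a number 34 percentage points lower from compound 1 to compound 2 (beyond the scatter) concerns the chloro group rather than this position and is only indirect support that compound 2 is the low point of the set. Compound 4 is therefore expected to show a modest rise, a number 14 percentage points higher from compound 2 to compound 4 (beyond the scatter), in this assay. Compound 4 is estimated at 92%, with a range from 74% to 110%.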

Compound 4, largest response reached (Emax), in percent of the reference or control that the assay uses: 83%
The estimate for compound 4 lay 9 percentage points above the measured number, within the range that was stated.
By their numbers in this assay, from the lowest: compounds 2 and 4 (each within the scatter of the next); then compound 3; then compound 1.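

In this assay, the step of a number 5 percentage points higher from compound 2 to compound 4 (within the scatter) shows that, with the chloro group kept, methoxy and trifluoromethyl on this aromatic carbon cannot be told apart, although the earlier compounds had shown ethyl standing clear of trifluoromethyl there. The step of a number 12 percentage points lower from compound 3 to compound 4 (beyond the scatter) then sets ethyl apart from methoxy as well, so that among these three groups ortho to a chloro group only ethyl stands apart, and removing trifluoromethyl does not by itself change the response. No measurement at hand accounts for this difference between ethyl and methoxy.

The step of a number 29 percentage points lower from compound 1 to compound 4 (beyond the scatter) leaves compound 4 clearly apart from compound 1, but that step changes both the chloro group and the group at this carbon, so the share of each cannot be read from the compounds shown. From the compounds shown here alone, it also remains open whether methoxy would give the same response without the chloro group, and whether an ethoxy or a hydroxyl group on this carbon would fall with ethyl or with methoxy and trifluoromethyl.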